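A methyl added to a series resting at its limit

The source may report more compounds than this note shows. Statements on the series, on what has been measured and on what is new or still open speak of the compounds shown alone.

In a functional assay on MDA-MB-231 cells (Homo sapiens) for antiproliferative activity, read by CCK-8 assay, with a stated time of 48 h (on this read-out higher numbers stand for weaker inhibition and lower numbers for stronger inhibition), compound 3 (`C=CC(=O)N1CC(Oc2ccc(Oc3c(-c4ccc(F)cc4)sc4cc(O)ccc34)cc2)C1`) gives > 50000 nM as a limit and not a number. Compound 1 (`C/C=C/C(=O)N1CC(Oc2ccc(Oc3c(-c4ccc(F)cc4)sc4cc(O)ccc34)cc2)C1`) gives > 50000 nM as a limit too. Compound 2 (`O=C(/C=C/CN1CC(Oc2ccc(Oc3c(-c4ccc(F)cc4)sc4cc(O)ccc34)cc2)C1)N1CCC1`) likewise gives > 50000 nM as a limit. Compound 3 therefore holds no rank of its own, since the series shows only the limit of > 50000 nM in this assay, at which 3 of the 3 values shown sit, and nothing finer.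

Compound 4 (`C=C(C)C(=O)N1CC(Oc2ccc(Oc3c(-c4ccc(F)cc4)sc4cc(O)ccc34)cc2)C1`) differs from compound 3 by methyl in place of hydrogen on a double-bonded chain carbon bound to a carbonyl carbon in a single place, with methyl in place of hydrogen on a double-bonded chain carbon bound to a carbonyl carbon. The closest measured change, vinyl in place of prop-1-en-1-yl on a carbonyl carbon, is a step that the two limits leave unreadable from compound 1 to compound 3 and offers no size. The two remaining changes are a step that the two limits leave unreadable from compound 1 to compound 2 and a step that the two limits leave unreadable from compound 2 to compound 3 and offer none either.

With no readable step to go on, no shift beyond the usual scatter is expected in either direction. The expected change is a number no higher from compound 3 to compound 4 (the limit leaves the size open) and no clear gain in inhibition is foreseen. The estimate for compound 4 is 50000 nM with an expected range from 25000 nM to 100000 nM and the result will most likely be reported as a limit again.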

Compound 4, half-maximal inhibitory concentration: > 50000 nM
Compound 4 gave a limit, no number; the forecaster's own chance of this, stated with the estimate: 85%; the middle value lies on the limit itself.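

In this assay compound 4 gives > 50000 nM, a limit and not a number. For the compounds shown here, no step from compound 1, compound 2 or compound 3 to compound 4 can be read, and the series stays at a single limit: the limit of > 50000 nM in this assay, at which 4 of the 4 values shown sit. The compounds shown leave open whether any of these changes alters inhibition at all, and how the four compounds rank.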